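The source may report more compounds than this note shows. Statements on the series, on what has been measured and on what is new or still open speak of the compounds shown alone.

Measured in a functional assay on HeLa cells (Homo sapiens); on this read-out higher numbers stand for weaker inhibition and lower numbers for stronger inhibition:

Compound 1, `Cc1ccc(C(=O)CC(SCC(=O)O)C(=O)O)c(C)c1`, gives 3830 nM.
Compound 2, `Cc1ccc(C)c(C(=O)CC(SCC(=O)O)C(=O)O)c1`, gives 2680 nM.
Compound 3, `CCc1ccc(C(=O)CC(SCC(=O)O)C(=O)O)cc1`, gives 4790 nM.

Of the three numbers, that of compound 3 is the top one, yet its gaps to compound 1 and to compound 2 both lie within the scatter, so the three compounds cannot be told apart in this assay. Among the measured compounds shown here, no single-point step between two measured compounds exists here, so nothing shows how a change of this kind moves the number.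

Compound 4, `O=C(O)CSC(CC(=O)c1ccc(Cl)cc1)C(=O)O`, has not yet been measured. It differs from compound 3 by chloro in place of ethyl on an aromatic carbon. For the measured compounds named here, with no comparable step among the measured compounds, the expected step from compound 3 to compound 4 in this assay is a 1.4-fold lower number from compound 3 to compound 4 (0.14 log units; within the scatter), that is, none beyond the scatter. For compound 4 the estimated value is 3500 nM, expected between 1200 nM and 10000 nM.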

Compound 4, half-maximal inhibitory concentration: 17300 nM
Compound 4: the middle estimate sits 4.9-fold (0.69 log units) below what was measured, and the stated range ends below it.
By their numbers in this assay, from the lowest: compounds 2, 1 and 3 (each within the scatter of the next); then compound 4.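

In this assay, among the compounds shown here, putting chloro in place of ethyl on the aromatic carbon para to a large group gives the first step here beyond the scatter (a 3.6-fold higher number from compound 3 to compound 4 (0.56 log units; beyond the scatter)). So the number at this position does respond to what the ring carries, which the earlier compounds could not show. Nothing at hand explains the rise.

As far as these compounds go, with one such pair, it stays open whether losing ethyl or gaining chloro matters more. Fluoro, methoxy or a longer chain such as propyl at this place would be the next groups to compare.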